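This account rests on a few compounds, and the source may have more. Where it says the series, first, only, none or still open, it means among the compounds named here.

In an ADME assay on L6 cells (Rattus norvegicus) for cytotoxicity, read by resazurin assay, with a stated time of 72 h (a lower number here means a stronger inhibitor, a higher number a weaker inhibitor), compound 2 (`CC(C)Oc1ccc(C(O)(c2ccc(C(F)(F)F)cc2)c2cccnc2)cc1`) gives 47600 nM, within the scatter of compound 1 (`OC(c1ccc(Cl)cc1)(c1ccc(Br)cc1)c1cccnc1`) at 57000 nM. Compound 3 (`OC(c1ccc(Br)cc1)(c1ccc(C(F)(F)F)cc1)c1cccnc1`) has bromo in place of isopropoxy on an aromatic carbon of compound 2, para to a large group: bromo in place of isopropoxy on an aromatic carbon. No measured step sizes this change. Compound 1, which also carries bromo, stands at 57000 nM, so no shift beyond the scatter is expected in this assay. The estimated 1.1-fold higher number from compound 2 to compound 3 (0.02 log units; within the scatter) is therefore small. For compound 3 the expected value is 50000 nM, with an estimated range of 22000 nM to 100000 nM.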

Compound 3, half-maximal inhibitory concentration: 54700 nM
For compound 3 the middle estimate is 1.1-fold (0.04 log units) below the measured one, and the stated range covers the measured number.
By their numbers in this assay, from the lowest: compounds 2, 3 and 1 (each within the scatter of the next).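

In this assay, for the compounds shown here, bromo in place of isopropoxy on an aromatic carbon, para to a large group, is the first exchange sized at this place (a 1.1-fold higher number from compound 2 to compound 3 (0.06 log units; within the scatter)), and trifluoromethyl in place of chloro on an aromatic carbon is sized as well (a 1.0-fold lower number from compound 1 to compound 3 (0.02 log units; within the scatter)). Neither step goes beyond the scatter, so replacing the whole isopropoxy group with bromo leaves the number unmoved here. No measurement at hand offers an explanation for this. Going by these compounds, whether an amine or a carboxylic acid at this place would move the number beyond the scatter stays open, as does the effect of any change to the shared core.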